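Trifluoromethyl to sulfamoyl: expecting only a small shift

This account rests on a few compounds, and the source may have more. Where it says the series, first, only, none or still open, it means among the compounds named here.

Measured so far in a functional assay on RPMI-8226 cells (Homo sapiens) for inhibition; on this read-out lower numbers stand for stronger inhibition and higher numbers for weaker inhibition:
- compound 1 `N#CC1CN1C(=O)Nc1ccc(F)cc1` gives 5900 nM
- compound 2 `CCOC(=O)c1ccc(NC(=O)N2CC2C#N)cc1` gives 3000 nM
- compound 3 `N#CC1CN1C(=O)Nc1ccc(C(F)(F)F)cc1` gives 7800 nM

Compound 3 has the highest number of the three. Its nearest neighbour is compound 1, where a 1.3-fold higher number from compound 1 to compound 3 (0.12 log units; within the scatter); the furthest is compound 2, where a 2.6-fold higher number from compound 2 to compound 3 (0.41 log units; beyond the scatter). Compound 4 `N#CC1CN1C(=O)Nc1ccc(S(N)(=O)=O)cc1` has not yet been measured; it differs from compound 3 in one place: sulfamoyl in place of trifluoromethyl on an aromatic carbon.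

Going by the values given here, two measured steps bear on this change, both exchanging the same group on the aromatic ring: the step from fluoro to trifluoromethyl stayed within the scatter, and the step from ethoxycarbonyl to trifluoromethyl gave a modest rise. Neither exchange moved the number far, so a small step is expected here too, most likely a modest drop in this assay , since the group entering, like ethoxycarbonyl in compound 2 3000 nM, carries hydrogen-bond acceptors. The expected step is a 2.0-fold lower number from compound 3 to compound 4 (0.29 log units; within the scatter), and compound 4 is estimated at 4000 nM, within a range of 1500 nM to 12000 nM.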

Compound 4, half-maximal inhibitory concentration: > 38000 nM
Compound 4: a limit, no number; the forecaster's own chance of this, stated with the estimate: 10%; middle value at least 9.5-fold (0.97 log units) from the limit.
By their numbers in this assay, from the lowest: compounds 2, 1 and 3 (each within the scatter of the next, the first and the last beyond it). At a limit, above all of these: compound 4.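

In this assay compound 4 gives no number, only a limit: the limit of > 38000 nM in this assay, at which 1 of the 4 values shown sits.

Fluoro, ethoxycarbonyl and trifluoromethyl at this ring position stayed within a modest span, whereas sulfamoyl gives an at least 4.8-fold higher number from compound 3 to compound 4 (0.68 log units; beyond the scatter), an at least 6.4-fold higher number from compound 1 to compound 4 (0.80 log units; beyond the scatter) and an at least 12-fold higher number from compound 2 to compound 4 (1.10 log units; beyond the scatter), so this position does not accept every group equally. Trifluoromethyl and sulfamoyl both hold 4 heavy atoms, so matching that count does not preserve the read-out here.

The compounds shown do not tell whether the hydrogen-bond donor of sulfamoyl goes with this loss, a question that a methylsulfonyl group at the same place could help to answer. They also leave open how far the read-out would move with an amine or a carboxylic acid on this aromatic carbon.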